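Fluoro shift: 3-fluorophenyl to 4-fluorophenyl

A few compounds are considered here, and "the series" means these few. Any claim that something is new, unique, unknown or untested is made for them only; others in the source may bear on it.

Measured in a toxicity assay on MT4 cells (Homo sapiens) for cytotoxicity, read by MTT assay; a higher number here means that more compound is tolerated, a lower number that less compound is tolerated:
- compound 1 `Cc1cc(-c2ccccc2)cc(C)c1Oc1cc(N)nc(Nc2ccc(C#N)cc2)n1`: 25600 nM
- compound 2 `Cc1cc(-c2cccc(F)c2)cc(C)c1Oc1cc(N)nc(Nc2ccc(C#N)cc2)n1`: 24700 nM

Compound 2 stands level with compound 1, within the scatter, and no other number is available for comparison. Compound 3 `Cc1cc(-c2ccc(F)cc2)cc(C)c1Oc1cc(N)nc(Nc2ccc(C#N)cc2)n1` brings 4-fluorophenyl in place of 3-fluorophenyl on an aromatic carbon. Within the data shown here, the only measured step bearing on this is a 1.0-fold lower number from compound 1 to compound 2 (0.02 log units; within the scatter), fluoro in place of hydrogen, and it stays within the scatter. No shift beyond the scatter is therefore expected in this assay. The expected step is a 1.0-fold higher number from compound 2 to compound 3 (0.01 log units; within the scatter). The estimate for compound 3 is 25000 nM, with an expected range of 13000 nM to 45000 nM.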

Compound 3, half-maximal cytotoxic concentration: 23100 nM
Estimate against measurement, compound 3: 1.1-fold (0.03 log units) above; measured number inside the range.
By their numbers in this assay, from the lowest: compounds 3, 2 and 1 (each within the scatter of the next).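

In this assay, 4-fluorophenyl in place of 3-fluorophenyl gives a 1.1-fold lower number from compound 2 to compound 3 (0.03 log units; within the scatter), so moving the fluoro on this ring does not separate the two compounds. Fluoro in place of hydrogen at this second placement gives a 1.1-fold lower number from compound 1 to compound 3 (0.04 log units; within the scatter), so neither fluoro placement shown departs from compound 1 beyond the scatter. Nothing available here accounts for these numbers.

As far as these compounds go, whether a methoxy group, a carboxylic acid or an amine on this ring would shift the number beyond the scatter remains open.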